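A few compounds are considered here, and "the series" means these few. Any claim that something is new, unique, unknown or untested is made for them only; others in the source may bear on it.

Compounds measured so far in a functional assay on MCF7 cells (Homo sapiens) for inhibition, read by MTT assay, with a stated time of 72 h; on this read-out higher numbers stand for weaker inhibition and lower numbers for stronger inhibition:

Compound 1, `CN1C(=O)N(C)C2C1NC(=S)N2/N=C/C=C/c1ccccc1`: > 100000 nM
Compound 2, `COc1ccc(/C=C/C=N/N2C(=S)NC3C2N(C)C(=O)N3C)cc1`: > 100000 nM

Among the measured compounds shown here, compound 1 sits only at a limit of this assay, and the one further value shown is a limit as well. For compound 2, the value is likewise a limit of this assay. The step that the two limits leave unreadable from compound 1 to compound 2 therefore cannot be read in size, and the limit of > 100000 nM in this assay, at which 2 of the 2 values shown sit, is all that the two values convey.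

Compound 3, `CN1C(=O)N(c2ccccc2)C2NC(=S)N(/N=C/C=C/c3ccccc3)C21`, is not yet measured. It differs from compound 1 by phenyl in place of methyl on an amide-type nitrogen in a ring. For the measured compounds named here, no measured step touches this amide-type nitrogen, and the only step known, from compound 1 to compound 2, is unreadable, so no direction can be taken from it for this assay.

With both measured values at the limit, compound 3 is expected to stay near that limit, which makes the estimated step that the limit leaves unreadable from compound 1 to compound 3 and the estimate for compound 3 150000 nM, with a range from 30000 nM to 800000 nM.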

Compound 3, half-maximal inhibitory concentration: > 100000 nM
Compound 3 ended at the assay's limit; the forecaster's own chance of this, stated with the estimate: 75%; the middle value lies beyond the limit too.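

Compound 3, like compound 1, ends at a limit in this assay, so no size can be read for the change from methyl to phenyl: the limit of > 100000 nM in this assay, at which 3 of the 3 values shown sit.

The compounds shown leave open where any of the three stands beyond that limit, and so what either change does to inhibition.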